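The source may hold more compounds than are shown below. What is called first, only, known or untested is meant among the compounds shown, and "the series" means these compounds.

Compound 1 `COc1ccc(C2=C(c3cc(OC)c(OC)c(OC)c3)C(=O)CC2O[SiH2]C(C)(C)C)cc1` carries a silicon-bearing group on an oxygen, and in an ADME assay on HT-29 cells (Homo sapiens) for cytotoxicity, read by MTT assay, with a stated time of 72 h (a lower number here means a stronger inhibitor, a higher number a weaker inhibitor), compound 1 gives > 100 ug/mL, which is a limit and not a number. Compound 2 `COc1ccc(C2=C(c3cc(OC)c(OC)c(OC)c3)C(=O)C(OC(C)=O)C2)cc1Cl` gives < 1 ug/mL, also a limit. Compound 3 `COc1ccc(C2=C(c3cc(OC)c(OC)c(OC)c3)C(=O)CC2O)cc1`, with a hydrogen on that oxygen, gives 15 ug/mL. Within the data shown here, that swap is the only measured step, an at least 6.6-fold lower number from compound 1 to compound 3 (0.82 log units; beyond the scatter). Compound 4 `COCOc1cc(C2=C(c3cc(OC)c(OC)c(OC)c3)C(=O)CC2O[SiH2]C(C)(C)C)ccc1OC` keeps the silicon-bearing group and differs instead on an aromatic carbon: methoxymethoxy in place of hydrogen on an aromatic carbon. Among the measured compounds shown here, no measured step tests methoxymethoxy in place of hydrogen, so the swap above offers no size to carry over. The expected result, a number no higher from compound 1 to compound 4 (the limit leaves the size open), is no change beyond the scatter. Compound 4 is estimated at 100 ug/mL, with an expected range from 30 ug/mL to 300 ug/mL.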

Compound 4, half-maximal inhibitory concentration: 43 ug/mL
For compound 4 the middle estimate is 2.3-fold (0.37 log units) above the measured one; the measured number falls inside the stated range.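

In this assay, methoxymethoxy in place of hydrogen gives an at least 2.3-fold lower number from compound 1 to compound 4 (0.36 log units; beyond the scatter). This is the first step shown on the aromatic ring rather than on the oxygen, and it shows that this carbon, ortho to a methoxy group, can take a new group and shift the number while the silicon-bearing group stays in place. For compound 1 the starting point is a limit and not a number, so the full size of the step stays open: the limit of > 100 ug/mL in this assay, at which 1 of the 4 values shown sits.

On these data alone, whether an amine on this carbon would move the number as far stays open. So does whether methoxymethoxy would shift the number in the same direction in compound 3, which has a hydrogen on that oxygen.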